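This account rests on a few compounds, and the source may have more. Where it says the series, first, only, none or still open, it means among the compounds named here.

Compound 1 `CCc1ccc(C(=O)NC(=O)c2ccccc2O)cc1` is tested in an ADME assay on L6 cells (Rattus norvegicus) for cytotoxicity, read by resazurin assay, with a stated time of 72 h (on this read-out lower numbers stand for stronger inhibition and higher numbers for weaker inhibition), where compound 1 gives 70 ug/mL, the higher of the two plain numbers seen here, though its gap to compound 2 lies within the scatter. Compound 2 `N#Cc1ccc(C(=O)NC(=O)c2ccccc2O)cc1` gives 55 ug/mL in this assay, and the step of a 1.3-fold lower number from compound 1 to compound 2 (0.10 log units; within the scatter) is small. Compound 3 `CS(=O)(=O)c1ccc(C(=O)NC(=O)c2ccccc2O)cc1` reaches only a limit of the assay, > 100 ug/mL. The steps of an at least 1.4-fold higher number from compound 1 to compound 3 (0.15 log units; that floor lies within the scatter) and an at least 1.8-fold higher number from compound 2 to compound 3 (0.25 log units; that floor lies within the scatter) both stop at that limit (the limit of > 100 ug/mL in this assay, at which 1 of the 3 values shown sits). Compound 4 `CCOc1ccc(C(=O)NC(=O)c2ccccc2O)cc1` differs from compound 1 by ethoxy in place of ethyl on an aromatic carbon. Among the compounds with values here, no measured step puts ethoxy in place of ethyl, and the three steps seen all stay within the scatter, so no change beyond it is expected in this assay. Compound 4 is therefore estimated at 80 ug/mL, with a range from 40 ug/mL to 160 ug/mL, which means an expected step of a 1.1-fold higher number from compound 1 to compound 4 (0.06 log units; within the scatter).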

Compound 4, half-maximal inhibitory concentration: 17 ug/mL
Estimate against measurement, compound 4: 4.7-fold (0.67 log units) above; measured number outside the range, below it.
By their numbers in this assay, from the lowest: compound 4; then compounds 2 and 1 (each within the scatter of the next). At a limit, above all of these: compound 3.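

Ethoxy in place of ethyl adds one oxygen and one hydrogen-bond acceptor on this aromatic carbon, and in this assay it gives the first steps at this position that clearly pass the scatter: a 4.1-fold lower number from compound 1 to compound 4 (0.61 log units; beyond the scatter) and a 3.2-fold lower number from compound 2 to compound 4 (0.51 log units; beyond the scatter). So this position can respond to a small change, which compounds 1 to 3 did not show. The step of an at least 5.8-fold lower number from compound 3 to compound 4 (0.76 log units; beyond the scatter) also passes the scatter, but it starts from a limit of the assay: the limit of > 100 ug/mL in this assay, at which 1 of the 4 values shown sits.

On these data alone, whether the oxygen itself or the longer group matters stays open. Methoxy, a propoxy chain or an amine at this place would help to separate the two.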